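This account rests on a few compounds, and the source may have more. Where it says the series, first, only, none or still open, it means among the compounds named here.

Compound 3 `Cn1cc(-c2ccc(C(F)(F)F)cc2)c2cc(F)c(C(=O)NS(C)(=O)=O)cc21` and compound 1 `Cn1cc(-c2ccc(C(F)(F)F)cc2)c2cc(F)c(C(=O)NS(=O)(=O)C3CC3)cc21` share one core and differ only in one spot: cyclopropyl in place of methyl on a sulfonyl sulfur. In an ADME assay on a cell-free system (plasma, Homo sapiens) for protein binding (a lower number here means a smaller unbound share, a higher number a larger unbound share of the compound), compound 3 gives 0.002, and compound 1 gives 0.0025, so the exchange produced a 1.3-fold higher number from compound 3 to compound 1 (0.10 log units; within the scatter).

Compound 2 `CC(C)COc1ccc(-c2cn(C)c3cc(C(=O)NS(C)(=O)=O)c(F)cc23)cn1` is built on a different core; how the two cores differ is not broken down here. In this assay compound 2 gives 0.008, the highest of the three measured numbers, standing clear of compound 1 and compound 3 by more than the usual scatter.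

Compound 4 `CC(C)COc1ccc(-c2cn(C)c3cc(C(=O)NS(=O)(=O)C4CC4)c(F)cc23)cn1` has not yet been measured. It stands to compound 2 as compound 1 stands to compound 3: cyclopropyl in place of methyl on a sulfonyl sulfur. Since the surroundings of the exchange are the same in both pairs, this counts as the same change. The expected step is a 1.2-fold higher number from compound 2 to compound 4 (0.07 log units; within the scatter), resting on the fact that the same change gave a 1.3-fold higher number from compound 3 to compound 1 (0.10 log units; within the scatter). On that basis compound 4 is estimated at 0.0095 in this assay, expected to fall between 0.005 and 0.018.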

Compound 4, unbound fraction: 0.024
Estimate against measurement, compound 4: 2.5-fold (0.40 log units) below, and the stated range ends below it.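

In this assay, cyclopropyl in place of methyl on a sulfonyl sulfur gave a 3.0-fold higher number from compound 2 to compound 4 (0.48 log units; beyond the scatter), a step larger than repeat measurements would usually produce. Set beside the earlier pair, this step does not differ from it by more than the scatter of two such steps, so the data give no firm ground for saying that the change behaves differently on the two cores: the same change on two cores in this assay, a 1.3-fold higher number (0.10 log units; within the scatter) from compound 3 to compound 1 and a 3.0-fold higher number (0.48 log units; beyond the scatter) from compound 2 to compound 4, 2.4-fold (0.38 log units) apart, within the scatter of two such steps. Going by these compounds alone, this does not prove that the step has the same size on both cores: there is only one pair per core, one step lies within the scatter and the other beyond it, and the reason for the rise remains unknown.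

The compounds shown leave open how other groups on the sulfonyl sulfur, such as ethyl or isopropyl, would compare with methyl and cyclopropyl on either core. They also leave open what a carboxylic acid in place of the (methylsulfonyl)carbamoyl group would do to the unbound fraction.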